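Phenol to methoxy on a pyrazole urea: expected step

This account rests on a few compounds, and the source may have more. Where it says the series, first, only, none or still open, it means among the compounds named here.

Compound 1 `O=C(Nc1cccc(-n2cc(-c3ccncc3)c(-c3cc(O)cc(Cl)c3)n2)c1)Nc1ccc(Cl)c(Cl)c1` gives 104% in a functional assay on DU-145 cells (Homo sapiens) for inhibition, read by sulforhodamine B assay, with a stated time of 48 h, tested at 0.1 uM (on this read-out higher numbers stand for a weaker effect at the one concentration tested and lower numbers for a stronger effect), the larger of the two readings obtained so far, though the gap to its nearest neighbour lies within the usual scatter. Compound 2 `COc1cc(Cl)cc(-c2nn(-c3cccc(NC(=O)Nc4cc(C(F)(F)F)cc(C(F)(F)F)c4)c3)cc2-c2ccncc2)c1` gives 95% in this assay; the two values are within scatter of each other, so neither compound can be called the weaker. Both carry a bis(trifluoromethyl)- or dichlorophenyl urea on the shared core and both show little effect at the single concentration used.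

Compound 3 `COc1cc(Cl)cc(-c2nn(-c3cccc(NC(=O)Nc4ccc(Cl)c(Cl)c4)c3)cc2-c2ccncc2)c1` differs from compound 1 by methyl in place of hydrogen on an oxygen on an aromatic ring. Among the measured compounds shown here, no measured pair isolates this change; compound 2 already carries the methoxy group together with a different urea and reads close to compound 1. The step is expected to be a number 4 percentage points lower from compound 1 to compound 3 (within the scatter), none beyond the scatter. Compound 3 is therefore estimated at 100%, with a range from 85% to 112%.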

Compound 3, a percentage reported as activity, at one concentration (the size of the read-out at that concentration, not a potency): 97%
Estimate against measurement, compound 3: 3 percentage points above; the measured number falls inside the stated range.
By their numbers in this assay, from the lowest: compounds 2, 3 and 1 (each within the scatter of the next).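

Among the compounds shown here, with the urea held constant, the exchange of hydroxy to methoxy on this assay reads as a number 7 percentage points lower from compound 1 to compound 3 (within the scatter), which gives the first view of this change on its own. Compound 2 carried the methoxy group only together with a different urea, so it could not separate the two changes. On an oxygen on an aromatic ring, hydrogen and methyl therefore cannot be told apart at the single concentration tested, and nothing available here offers an explanation for this reading.

As far as these compounds go, whether an amine, a carboxylic acid or an ethoxy group at this place would give a reading beyond the scatter remains open. Also open, from the compounds shown here alone, is whether hydroxy to methoxy reads the same with the urea of compound 2, or at a higher concentration, where the effect may be larger.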